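The source may hold more compounds than are shown below. What is called first, only, known or untested is meant among the compounds shown, and "the series" means these compounds.

Working notes on the series. Three compounds built on a shared amide-bearing core have been run in a toxicity assay on THP-1 cells (Homo sapiens) for inhibition; a lower number here means that less compound is tolerated, a higher number that more compound is tolerated: compound 1 `COc1ccc(-c2cnc(NC(=O)c3ccc(F)cc3)[nH]2)cc1`, compound 2 `COc1ccc2c(c1)nc(NC(=O)c1ccc(F)cc1)n2C` and compound 3 `COc1ccc(-c2cnc(NC(=O)c3ccccc3Br)n2C)cc1`. In this assay compound 1 returns only a limit of the assay, > 100000 nM. In this assay compound 2 likewise gives only a limit, > 100000 nM. In this assay compound 3 also stands at a limit rather than a number, > 100000 nM. All three readings thus sit at the same point: the limit of > 100000 nM in this assay, at which 3 of the 3 values shown sit. Among the measured compounds shown here, no numerical step between any two measured compounds can be drawn from this set.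

Compound 4 `COc1ccc(-c2cnc(NC(=O)c3ncc[nH]3)n2C)cc1` is the next member and differs from compound 3 in one place: 1H-imidazol-2-yl in place of 2-bromophenyl on a carbonyl carbon. The amide and the rest of the core are kept.

With every measured compound at the limit in this assay, compound 4 is expected to read in the same region. The step expected for compound 4 in this assay is a number no higher from compound 3 to compound 4 (the limit leaves the size open), that is none beyond the usual scatter in either direction. Compound 4 is therefore estimated at 100000 nM in this assay, with a range from 40000 nM to 300000 nM, and most likely another limit rather than a number.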

Compound 4, half-maximal cytotoxic concentration: > 100000 nM
Compound 4 ended at the assay's limit (the forecaster's own chance of this, stated with the estimate: 80%); the middle value lies on the limit itself.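

No step can be read between compound 3 and compound 4 in this assay, as each reading is a limit and not a number: the limit of > 100000 nM in this assay, at which 4 of the 4 values shown sit. The compounds shown leave open whether any change to the shared core or to the group on the carbonyl carbon would give a numerical reading in this assay at all.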